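Methoxy for Bromo on a Methylene Lactone

The compounds below may be only part of what the source reports. "The series", "measured", "known", "first", "only" and "open" are said of these compounds alone.

Three measured compounds share one core. Compound 1 `C=C1C(=O)O[C@H](C)[C@@H]1c1ccc([N+](=O)[O-])cc1` carries a nitro group on its aromatic ring and gives 1900 nM in a functional assay on L1210 cells (Mus musculus) for cytotoxicity, read by MTT assay, with a stated time of 48 h; a higher number here means a weaker inhibitor, a lower number a stronger inhibitor. Compound 2 `C=C1C(=O)O[C@H](C)[C@@H]1c1ccc(Br)cc1` carries a bromo group instead, and in this assay compound 2 gives 7800 nM, a step of a 4.1-fold higher number from compound 1 to compound 2 (0.61 log units; beyond the scatter). Compound 3 `C=C1C(=O)O[C@@H](C)[C@@H]1c1ccc(Br)cc1` has the same atoms and bonds as compound 2 and differs only in configuration, and in this assay compound 3 gives 580 nM, a step of a 13-fold lower number from compound 2 to compound 3 (1.13 log units; beyond the scatter); this rests on (the fact that compounds 2 and 3 differ only in the configuration as drawn). Compound 3 thus stands lowest of the three numbers.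

Compound 4 `C=C1C(=O)O[C@@H](C)[C@@H]1c1ccc(OC)cc1` keeps the configuration of compound 3 and differs in one place: methoxy in place of bromo on an aromatic carbon. Among the measured compounds shown here, no measured step swaps bromo for methoxy, and the only change of the aromatic substituent among the measured compounds is the nitro-to-bromo step from compound 1 to compound 2, of modest size and made on the other configuration. A change of the aromatic substituent is therefore expected to move this assay by a modest amount at most, in a direction that cannot be fixed from these data. Compound 4 is accordingly estimated at 900 nM, with a range from 300 nM to 2700 nM, a step of a 1.6-fold higher number from compound 3 to compound 4 (0.19 log units; within the scatter).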

Compound 4, half-maximal inhibitory concentration: 1950 nM
Beside the measured number, compound 4's estimate is 2.2-fold (0.34 log units) below it; the range from low to high includes it.
By their numbers in this assay, from the lowest: compound 3; then compounds 1 and 4 (each within the scatter of the next); then compound 2.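

In this assay, replacing bromo with methoxy on an aromatic carbon gives a 3.4-fold higher number from compound 3 to compound 4 (0.53 log units; beyond the scatter), which shows that the aromatic substituent also moves the number on this configuration and that here the change runs upward. The earlier compounds shown here showed a change of this substituent only on the other configuration, with a 4.1-fold higher number from compound 1 to compound 2 (0.61 log units; beyond the scatter), and that step, too, lies beyond the scatter. The two steps share bromo but stand on different configurations, so they place methoxy and nitro each against bromo and give no single order of the three groups, and nothing available accounts for the size or direction of the new step.

The compounds shown leave open what nitro would give on this configuration, what methoxy would give on the other, and therefore whether the effect of a substituent carries over from one configuration to the other. They also leave open how an amine, a carboxylic acid or a longer alkoxy chain at this place on the ring would compare with bromo and methoxy.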